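Benzyl for Cyclohexenyl: What to Expect for Compound 3

This account rests on a few compounds, and the source may have more. Where it says the series, first, only, none or still open, it means among the compounds named here.

Measured so far:
Compound 1, `O=C1O/C(=C\Cn2cc(C3=CCCCC3)nn2)C(OCc2ccccc2)=C1OCc1ccccc1`: > 100000 nM
Compound 2, `Cc1ccc(-c2cn(CCC3(O)NC(=O)C(OCc4ccccc4)=C3OCc3ccccc3)nn2)cc1`: 45000 nM

Of the compounds shown here, two have been tested in an ADME assay on HEK293 cells (Homo sapiens) for cytotoxicity, read by MTT assay, with a stated time of 24 h; a lower number here means a stronger inhibitor, a higher number a weaker inhibitor. Compound 1 gives > 100000 nM, and this is a limit of the assay, not a number. Compound 2 gives 45000 nM. Compound 1 therefore stands at the limit of > 100000 nM in this assay, at which 1 of the 2 values shown sits, so the only thing its result tells is that no half-maximal inhibition was reached within the tested range, while compound 2 did return a number.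

Compound 3 is `O=C1O/C(=C\Cn2cc(Cc3ccccc3)nn2)C(OCc2ccccc2)=C1OCc1ccccc1`. It differs from compound 1 in a single place: benzyl in place of cyclohex-1-en-1-yl on an aromatic carbon. For the measured compounds named here, no measured pair shows this particular change, so its effect has not been observed in these data.

Because compound 1 sits at the limit of > 100000 nM in this assay, at which 1 of the 2 values shown sits, the most likely outcome for compound 3 is estimated to be another limit. The expected step that the limit leaves unreadable from compound 1 to compound 3 is none beyond the scatter. Compound 3 is estimated at 120000 nM, with a range from 40000 nM to 350000 nM.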

Compound 3, half-maximal inhibitory concentration: 70000 nM
Compound 3: the middle estimate sits 1.7-fold (0.23 log units) above what was measured; low and high end bracket the measured number.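

In this assay, for the compounds shown here, exchanging cyclohex-1-en-1-yl for benzyl on an aromatic carbon of the five-membered ring with 3 nitrogen gives the first step that can be read at this position (an at least 1.4-fold lower number from compound 1 to compound 3 (0.15 log units; that floor lies within the scatter)). Only the floor of this step is known, and since that floor lies within the scatter, the data cannot say whether the change truly lowers the number or by how much. Compound 1 gives > 100000 nM, which is a limit of the assay and not a number, and the step has only a floor because of that limit: the limit of > 100000 nM in this assay, at which 1 of the 3 values shown sits.

The compounds shown leave open which part of the change matters, the aromatic ring of benzyl or the link that joins this ring to the triazole. Cyclohexylmethyl on the same aromatic carbon would help to separate these two parts, while an amine or a carboxylic acid on the benzyl ring would test whether the number moves further from the scatter.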